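Moving the acid and adding a methoxy on the far ring

The source may hold more compounds than are shown below. What is called first, only, known or untested is meant among the compounds shown, and "the series" means these compounds.

Measured compounds:
compound 1 `Cc1c(OCCCCOc2ccc(C(=O)O)cc2)ccc(C(=O)CC(C)C)c1O`, 88%
compound 2 `Cc1c(OCCCCOc2ccc(C(=O)O)cc2)ccc(C(=O)CC2CCCC2)c1O`, 82.6%
compound 3 `COC(=O)c1ccc(OCCCCOc2ccc(C(=O)CC3CCCC3)c(C)c2C)cc1`, 14.1%

In an assay on HEK293 cells for positive allosteric modulation of metabotropic glutamate receptor 2 (Rattus norvegicus), read by thallium flux, with a stated time of 2.5 min (on this read-out lower numbers stand for smaller maximal responses and higher numbers for larger maximal responses), compound 2 stands second highest of three numbers, within the scatter of compound 1 and far above compound 3. Within the data shown here, the only single-place step known, a number 5.4 percentage points lower from compound 1 to compound 2 (within the scatter), concerns a different part of the molecule and stays within the scatter. Compound 4 `COc1ccc(C(=O)O)cc1OCCCCOc1ccc(C(=O)CC2CCCC2)c(O)c1C` differs from compound 2 by 5-carboxy-2-methoxyphenyl in place of 4-carboxyphenyl on an oxygen on a saturated carbon. Among the measured compounds shown here, no measured step touches that ring, so the direction of the step is uncertain; the acid is kept, which compound 3, lacking it, suggests matters. Compound 4 is therefore expected to keep a fairly large response, at 65% with a range of 30% to 95%, a step of a number 17.6 percentage points lower from compound 2 to compound 4 (beyond the scatter).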

Compound 4, largest response reached (reported as percent of maximum), in percent of the reference or control that the assay uses: 91.8%
The estimate for compound 4 lay 26.8 percentage points below the measured number; low and high end bracket the measured number.
By their numbers in this assay, from the lowest: compound 3; then compounds 2, 1 and 4 (each within the scatter of the next).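

In this assay, putting 5-carboxy-2-methoxyphenyl in place of 4-carboxyphenyl gives a number 9.2 percentage points higher from compound 2 to compound 4 (within the scatter), so this far ring tolerates the moved acid together with the added methoxy. Both changes arrive in one step, so the result describes the pair and not either change alone. Nothing available explains why the response holds.

The compounds shown leave open what the moved acid and the methoxy each do separately. They also leave open whether a tetrazole in place of the carboxylic acid, or a longer chain to this ring, would keep the response.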